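Thiophene terminus in place of cyanophenyl on the tropane series

The source may report more compounds than this note shows. Statements on the series, on what has been measured and on what is new or still open speak of the compounds shown alone.

For the measured compounds named here, compound 2 `COC(=O)C1C2CCC3CCC1N(C/C2=C\c1ccc(-c2ccc(C#N)cc2)cc1)C3` carries the lowest number measured so far: in an assay with sodium-dependent dopamine transporter (Rattus norvegicus) as the target (on this read-out lower numbers stand for stronger inhibition and higher numbers for weaker inhibition), compound 2 gives 47 nM. Going by the values given here, the only other measured member, compound 1 `COC(=O)C1C2CCC3CCC1N(C/C2=C\c1ccc(-c2ccc(N(C)C)cc2)cc1)C3`, gives 1050 nM in this assay, and the step of a 22-fold lower number from compound 1 to compound 2 (1.35 log units; beyond the scatter) is the single structural comparison available.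

Compound 3 `COC(=O)C1C2CCC3CCC1N(C/C2=C\c1ccc(-c2cccs2)cc1)C3` differs from compound 2 in one place: thiophen-2-yl in place of 4-cyanophenyl on an aromatic carbon. Among the compounds with values here, no measured step covers this kind of change; the one step recorded concerns the substituent on the distal ring of compound 2 and not the removal of that ring itself. The size of a 22-fold lower number from compound 1 to compound 2 (1.35 log units; beyond the scatter) shows only that the terminal part of this side chain matters strongly for the read-out. Whether a thiophen-2-yl terminus falls on the side of compound 2 or of compound 1 cannot be read from the data, so the direction of the step is open and the range must be wide.

For compound 3 the expected value in this assay is 70 nM, between 15 nM and 350 nM, which corresponds to an expected step of a 1.5-fold higher number from compound 2 to compound 3 (0.17 log units; within the scatter).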

Compound 3, inhibition constant: 155 nM
For compound 3 the middle estimate is 2.2-fold (0.35 log units) below the measured one; low and high end bracket the measured number.
By their numbers in this assay, from the lowest: compound 2; then compound 3; then compound 1.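

Read in this assay, replacing 4-cyanophenyl with thiophen-2-yl gives a 3.3-fold higher number from compound 2 to compound 3 (0.52 log units; beyond the scatter), whereas replacing 4-(dimethylamino)phenyl with the same terminus gives a 6.8-fold lower number from compound 1 to compound 3 (0.83 log units; beyond the scatter). For the compounds shown here, the position therefore tolerates a five-membered aromatic ring with one hetero atom in place of a six-membered aromatic ring of carbon only, and a nitrile is not required for a number well under that of compound 1, although the best number so far still belongs to the 4-cyanophenyl terminus of compound 2. The order also does not follow ring size in one direction, since the two six-membered termini take the lowest and highest places with the thiophen-2-yl compound in the middle, and no measurement at hand explains this order.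

The three compounds do not separate the effect of changing the ring from the effect of losing the nitrile, a question that an unsubstituted phenyl terminus or a thiophene ring carrying a nitrile would address. Going by these compounds, it also remains open how other five- and six-membered termini, such as thiophen-3-yl, furan-2-yl or pyridin-3-yl, would rank against these three.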